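This account rests on a few compounds, and the source may have more. Where it says the series, first, only, none or still open, it means among the compounds named here.

Of the compounds shown here, three have been tested in a functional assay on HeLa cells (Homo sapiens) for inhibition, read by CCK-8 assay, with a stated time of 48 h; on this read-out lower numbers stand for stronger inhibition and higher numbers for weaker inhibition. Compound 1 `COc1cc(-c2cc3nccc(-c4c[nH]c5ccccc45)n3n2)cc(OC)c1OC` reaches only a limit of > 10000 nM and gives no number. Compound 2 `COc1cc(-c2ccnc3cc(-c4c[nH]c5ccccc45)nn23)cc(OC)c1OC` gives 195 nM and compound 3 `COc1cc(-c2ccnc3cc(-c4ccc(C)cc4)nn23)cc(OC)c1OC` gives 21 nM in the same test, so compound 3 holds the lower of the two actual numbers.

Compound 4 `COc1cc(-c2ccnc3cc(-c4ccc5c(ccn5C)c4)nn23)cc(OC)c1OC` departs from compound 3 at one place, an aromatic carbon of the five-membered aromatic ring with 2 nitrogen, where 1-methyl-1H-indol-5-yl stands in place of 4-methylphenyl: 1-methyl-1H-indol-5-yl in place of 4-methylphenyl on an aromatic carbon is the whole change.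

Among the measured compounds shown here, one measured step bears on this place. Placing 4-methylphenyl where compound 2 has 1H-indol-3-yl gave a 9.3-fold lower number from compound 2 to compound 3 (0.97 log units; beyond the scatter) as a modest change, so the group here does matter. That step says little about the incoming group, however, since 1-methyl-1H-indol-5-yl is not the 1H-indol-3-yl of compound 2. For the measured compounds named here, with only this evidence, a step beyond the scatter in this assay is not expected in either direction, and the value of compound 3 at 21 nM remains the best guide. The expected step runs a 1.2-fold lower number from compound 3 to compound 4 (0.07 log units; within the scatter) and would stay within the scatter. For compound 4 the estimated value is 18 nM with 5 nM to 70 nM as the expected range.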

Compound 4, half-maximal inhibitory concentration: 19 nM
Compound 4: middle estimate off by 1.1-fold (0.02 log units), on the low side; measured number inside the range.
By their numbers in this assay, from the lowest: compounds 4 and 3 (each within the scatter of the next); then compound 2. At a limit, above all of these: compound 1.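

In this assay, 1-methyl-1H-indol-5-yl in place of 4-methylphenyl gave a 1.1-fold lower number from compound 3 to compound 4 (0.04 log units; within the scatter) and so left the value unchanged within the scatter, which shows that this aromatic carbon of the five-membered aromatic ring with 2 nitrogen accepts the two-ring group as well as the single-ring one. The step with a 10-fold lower number from compound 2 to compound 4 (1.01 log units; beyond the scatter) shows what compound 2 alone could not: a two-ring group at this place does not by itself bring the higher number of compound 2, and which such group stands here decides the outcome. Nothing shown gives a cause for either step.

Compound 2 and compound 4 differ both in the methyl on the ring nitrogen and in the carbon through which the indole is attached, so it remains open which of the two accounts for the step between them. On these data alone, it also remains open how this place would respond to an amine, a carboxylic acid or a longer chain in place of these aromatic groups.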